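The source may hold more compounds than are shown below. What is called first, only, known or untested is meant among the compounds shown, and "the series" means these compounds.

Measured so far in an assay on membranes from brain for displacement of a labelled ligand from Sigma non-opioid intracellular receptor 1 (Cavia porcellus), read by scintillation counting, with a stated time of 120 min; on this read-out lower numbers stand for stronger inhibition and higher numbers for weaker inhibition:
- compound 1 `c1ccc(CCCNC2CCc3ccsc3CC2)cc1`: compound 1 gives 187 nM
- compound 2 `c1ccc(CCCCNC2CCc3ccsc3CC2)cc1`: compound 2 gives 62 nM
- compound 3 `CN(CCCc1ccccc1)C1CCc2ccsc2CC1`: compound 3 gives 10 nM

Compound 3 holds the lowest number of the three. Among the measured compounds shown here, its nearest neighbour is compound 2, which sits well above it, and compound 1 stands furthest away: the single change of methyl in place of hydrogen on the amine nitrogen gives a 19-fold lower number from compound 1 to compound 3 (1.27 log units; beyond the scatter), a large step. For the measured compounds named here, no single-point step links compound 2 and compound 3; the two values simply show compound 3 to be the lower of the pair.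

Compound 4 `CN(CCCCc1ccccc1)C1CCc2ccsc2CC1` differs from compound 3 by benzyl in place of phenyl on a saturated chain carbon, three bonds along the chain from an amine nitrogen. The same change has been measured once in this series, on the unmethylated pair, where it gave a 3.0-fold lower number from compound 1 to compound 2 (0.48 log units; beyond the scatter), a modest lowering. Nothing measured contradicts carrying that over to the methylated amine, so a step of similar size and direction in this assay is expected, namely a 2.5-fold lower number from compound 3 to compound 4 (0.40 log units; beyond the scatter), with some allowance for the step being smaller once the number is already low. On that basis compound 4 is estimated at 4 nM, with a range of 1.5 nM to 12 nM.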

Compound 4, inhibition constant: 17 nM
The estimate for compound 4 lay 4.3-fold (0.63 log units) below the measured number; measured number above the stated range.
By their numbers in this assay, from the lowest: compounds 3 and 4 (each within the scatter of the next); then compound 2; then compound 1.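

In this assay, benzyl in place of phenyl on a saturated chain carbon, three bonds along the chain from an amine nitrogen, does not repeat its effect once that nitrogen carries methyl; the step is now a 1.7-fold higher number from compound 3 to compound 4 (0.23 log units; within the scatter), and the lowering seen with hydrogen on the nitrogen does not carry over: the same change on two cores in this assay, a 3.0-fold lower number (0.48 log units; beyond the scatter) from compound 1 to compound 2 and a 1.7-fold higher number (0.23 log units; within the scatter) from compound 3 to compound 4, 5.1-fold (0.71 log units) apart, beyond the scatter of two such steps Methyl in place of hydrogen on the amine nitrogen still helps on the benzyl side, with a 3.6-fold lower number from compound 2 to compound 4 (0.56 log units; beyond the scatter), but this step is smaller than the one on the phenyl side: the same change on two cores in this assay, a 19-fold lower number (1.27 log units; beyond the scatter) from compound 1 to compound 3 and a 3.6-fold lower number (0.56 log units; beyond the scatter) from compound 2 to compound 4, 5.1-fold (0.71 log units) apart, beyond the scatter of two such steps Across these four compounds the two changes therefore do not add, and the size of each depends on the group present at the other place.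

The compounds shown leave open whether a longer chain on the methylated amine would keep the number level with the values of compound 3 and compound 4 or move it beyond the scatter. They also leave open whether ethyl in place of methyl on the amine nitrogen would follow the same dependence on the chain.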